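Changing the Aromatic Ester Group on a Shared Core

The compounds below may be only part of what the source reports. "The series", "measured", "known", "first", "only" and "open" are said of these compounds alone.

Two esters of the shared core have been measured so far in a toxicity assay on cells (Fibroblast, Homo sapiens) for cytotoxicity (on this read-out lower numbers stand for stronger inhibition and higher numbers for weaker inhibition), and no more. Compound 1 `CC(/C=C/C1=CCCCC1(C)C)=C\C=C\C(C)=C\COC(=O)c1cc(O)ccc1O` gives 14000 nM there, while compound 2 `COc1ccc(O)c(C(=O)OC/C=C(C)/C=C/C=C(C)/C=C/C2=CCCCC2(C)C)c1` gives 570000 nM as the higher of the two numbers. For the measured compounds named here, the one measured step shows a 41-fold higher number from compound 1 to compound 2 (1.61 log units; beyond the scatter) and is large, with methyl in place of hydrogen on an oxygen on an aromatic ring. Compound 3 `CC(/C=C/C1=CCCCC1(C)C)=C\C=C\C(C)=C\COC(=O)c1ccc(O)cc1O` differs from compound 2 on a carbonyl carbon, where 2,4-dihydroxyphenyl stands in place of 2-hydroxy-5-methoxyphenyl (2,4-dihydroxyphenyl in place of 2-hydroxy-5-methoxyphenyl on a carbonyl carbon). Compound 3 has no methyl on that oxygen, like compound 1 at 14000 nM and unlike compound 2, so a large step to a lower number is expected, though its aromatic group is not that of compound 1. The expected change is a 29-fold lower number from compound 2 to compound 3 (1.45 log units; beyond the scatter) by this reasoning. The estimate for compound 3 is 20000 nM in this assay with an expected range from 6000 nM to 90000 nM overall.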

Compound 3, half-maximal inhibitory concentration: 120000 nM
Compound 3: middle estimate off by 6.0-fold (0.78 log units), on the low side; measured number outside the range, above it.
By their numbers in this assay, from the lowest: compound 1; then compound 3; then compound 2.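

In this assay, losing the methyl does not by itself bring the number back to that of compound 1: the change of aromatic group gives a 4.8-fold lower number from compound 2 to compound 3 (0.68 log units; beyond the scatter), yet the free dihydroxyphenyl ester still shows an 8.6-fold higher number from compound 1 to compound 3 (0.93 log units; beyond the scatter). Thus 2,4-dihydroxyphenyl and 2,5-dihydroxyphenyl are not interchangeable on this carbonyl carbon, although both carry free hydroxyl groups, and the placing of those groups on the ring counts here as well as their being free. Nothing available explains this difference.

The compounds shown leave open whether the gap between the two dihydroxyphenyl esters would persist with an amine or a carboxylic acid on the ring in place of the second hydroxyl. They also do not tell whether a methyl on an oxygen of 2,4-dihydroxyphenyl would raise the number as much as in a 41-fold higher number from compound 1 to compound 2 (1.61 log units; beyond the scatter).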